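The source may report more compounds than this note shows. Statements on the series, on what has been measured and on what is new or still open speak of the compounds shown alone.

Compound 1 `CC1=NN(c2ccc(C)cc2)C(=O)[C@]12C(=O)C=CC[C@H]2c1ccc(C)cc1` and compound 2 `CC1=NN(c2ccc(C)cc2)C(=O)[C@@]12C(=O)C=CC[C@@H]2c1ccc(C)cc1` have the same atoms and bonds, and they are mirror images. In a functional assay on MDA-MB-231 cells (Homo sapiens) for inhibition, read by MTT assay, with a stated time of 72 h (a higher number here means a weaker inhibitor, a lower number a stronger inhibitor), compound 1 gives 8280 nM and compound 2 gives 8120 nM. Compound 2 therefore stands level with compound 1, and the measured step is a 1.0-fold lower number from compound 1 to compound 2 (0.01 log units; within the scatter). That step comes with the fact that compounds 1 and 2 differ only in the configuration as drawn, and inverting both stereocentres together left the number within the scatter.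

Compound 3 `CC1=NN(c2ccc(C)cc2)C(=O)[C@]12C(=O)C=CC[C@@H]2c1ccc(C)cc1` has not yet been measured. It departs from compound 2 by the two compounds have the same atoms and bonds and differ only in configuration as drawn: 1 of 2 stereo elements differ; a stereocentre at a saturated ring carbon is drawn R in compound 2 and S in compound 3, so nothing leaves or enters and only one of the two stereo elements differs. Among the compounds with values here, only the mirror-image pair bears on this change, and it offers indirect guidance, since no measured step inverts a single stereocentre. Given the step of a 1.0-fold lower number from compound 1 to compound 2 (0.01 log units; within the scatter) for compound 2, no shift beyond the scatter is expected in this assay, though the range is kept wide. The expected change is a 1.1-fold higher number from compound 2 to compound 3 (0.04 log units; within the scatter). For compound 3 the estimated value is 9000 nM, with an expected range from 3500 nM to 25000 nM.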

Compound 3, half-maximal inhibitory concentration: 57200 nM
Compound 3: the middle estimate sits 6.4-fold (0.80 log units) below what was measured; the whole stated range lies below it.
By their numbers in this assay, from the lowest: compounds 2 and 1 (each within the scatter of the next); then compound 3.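

Inverting a single stereocentre does what inverting both together did not: in this assay it gives a 7.0-fold higher number from compound 2 to compound 3 (0.85 log units; beyond the scatter), and the other single inversion gives a 6.9-fold higher number from compound 1 to compound 3 (0.84 log units; beyond the scatter). Both steps end at the same compound, so the relative arrangement of the two stereocentres, which compounds 1 and 2 share and compound 3 does not, matters in this assay, even though swapping compounds 1 and 2 for each other's mirror image changed nothing beyond the scatter. The loss can be put down to spatial arrangement alone, because no atom or bond changes along the way: the fact that compounds 2 and 3 differ only in the configuration as drawn

The compounds shown leave open whether the mirror image of compound 3 would stand level with compound 3 or apart from it, and so whether the weaker number belongs to this relative arrangement as such or to only one of its two mirror forms. They also leave open whether the same gap between arrangements would persist if a methoxy group or a chlorine atom took the place of a methyl group.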